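The compounds below may be only part of what the source reports. "The series", "measured", "known", "first", "only" and "open" are said of these compounds alone.

Measured compounds:
compound 1, `CC(C)c1onc(-c2ccc(S(C)(=O)=O)cc2Cl)c1COc1ccc(/C=C/c2cccc(C(=O)O)c2)c(Cl)c1` — 170 nM
compound 2, `Cc1cc(OCc2c(-c3c(Cl)ccc(=O)n3C)noc2C(C)C)ccc1-c1ccc2c(C(=O)O)cn(C)c2c1` — 235 nM

Both compounds were tested in an assay on isolated protein for displacement of a labelled ligand from Bile acid receptor (Homo sapiens), read by scintillation proximity assay and radioligand binding; a higher number here means a weaker inhibitor, a lower number a stronger inhibitor. Compound 1 gives 170 nM and compound 2 gives 235 nM; the two numbers lie within the usual scatter of each other, so compound 2 does not stand apart from compound 1 on these two results, and no ordering between them can be read from the data.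

Compound 3, `Cc1cc(OCc2c(-c3[nH]c(=O)ccc3Cl)noc2C(C)C)ccc1-c1ccc2c(C(=O)O)cn(C)c2c1`, has not yet been measured. It differs from compound 2 in one place: hydrogen in place of methyl on an aromatic nitrogen. No measured pair in this set shares this change, so its effect on the readout is not known from the data shown.

With nothing to anchor the step, a small step is expected, in either direction, most likely none beyond the scatter: the estimated step from compound 2 to compound 3 is a 1.3-fold higher number from compound 2 to compound 3 (0.11 log units; within the scatter). On that basis compound 3 is expected to give about 300 nM in this assay, with a range from 110 nM to 850 nM.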

Compound 3, half-maximal inhibitory concentration: 4130 nM
Beside the measured number, compound 3's estimate is 14-fold (1.14 log units) below it, and the stated range ends below it.
By their numbers in this assay, from the lowest: compounds 1 and 2 (each within the scatter of the next); then compound 3.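

In this assay, hydrogen in place of methyl on an aromatic nitrogen gives an 18-fold higher number from compound 2 to compound 3 (1.24 log units; beyond the scatter), a large step for the loss of a single carbon. Going by these compounds alone, until this pair, no two compounds differing in only one place were available, so nothing showed whether any single position mattered. This position clearly does: with the rest of the structure unchanged, the methyl of compound 2 goes with much stronger inhibition than the hydrogen of compound 3, and the change cannot be treated as a minor edit. Within the data shown here, this one pair is the only reading of the position, and nothing measured here bears on what lies behind the size of the step.

The compounds shown leave open whether the trend continues past methyl, since an ethyl group, a longer chain or a methoxyethyl group on the same nitrogen would be needed to tell whether inhibition strengthens further, holds or falls away. Among these compounds, they also leave open whether the same change has a step of similar size on a different core, as only one pair carries it.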